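A trifluoromethoxy swap on compound 2

This account rests on a few compounds, and the source may have more. Where it says the series, first, only, none or still open, it means among the compounds named here.

The study concerns three compounds built on one shared core. Compound 1 `FC(F)(F)Oc1ccc(Nc2nc3nonc3nc2Nc2ccc(OC(F)(F)F)cc2)cc1` carries trifluoromethoxy on both outer rings, whereas compound 2 `O=C(Nc1ccc(Nc2nc3nonc3nc2Nc2ccccc2F)cc1)C(F)(F)F` differs from it on both outer rings, one of them bearing ((trifluoromethyl)carbonyl)amino.

Among the measured compounds shown here, in an assay on mitochondria from L6 cells (Rattus norvegicus) for activation, with a stated time of 90 min (a higher number here means that more compound is needed for the effect, a lower number that less compound is needed), compound 2 gives 4100 nM, which is the only numeric value in the set. For compound 1 the result is a limit of the assay, < 5000 nM (the limit of < 5000 nM in this assay, at which 1 of the 2 values shown sits). For the measured compounds named here, no two measured compounds differ in a single place, so no measured step is available to calibrate any change.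

Compound 3 `Fc1ccccc1Nc1nc2nonc2nc1Nc1ccc(OC(F)(F)F)cc1` has not yet been measured. It arises from compound 2 by trifluoromethoxy in place of ((trifluoromethyl)carbonyl)amino on an aromatic carbon. Compound 3 thus keeps one outer ring of compound 2 and takes up the trifluoromethoxy ring that appears twice in compound 1. Going by the values given here, with no measured step to anchor this change, the step of a 1.2-fold lower number from compound 2 to compound 3 (0.07 log units; within the scatter) is expected to stay within the usual scatter. For compound 3 the estimated value in this assay is 3500 nM, with a range from 1000 nM to 12000 nM.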

Compound 3, half-maximal effective concentration: 1300 nM
Beside the measured number, compound 3's estimate is 2.7-fold (0.43 log units) above it; low and high end bracket the measured number.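

Among the compounds shown here, at this position, on an aromatic carbon of a six-membered aromatic ring of carbon only and para to a large group, trifluoromethoxy in place of ((trifluoromethyl)carbonyl)amino gives the first readable single-place change in this assay, with a 3.2-fold lower number from compound 2 to compound 3 (0.50 log units; beyond the scatter). Less compound is therefore needed after the change, even though the entering group has no hydrogen-bond donor and the group it replaces has one, so in this pair the amide hydrogen is not needed to reach the lower number. The result of compound 1 is a limit of the assay, and the step from compound 1 to compound 3 therefore cannot be read: the limit of < 5000 nM in this assay, at which 1 of the 3 values shown sits.

The compounds shown leave open whether the lower number comes from the presence of trifluoromethoxy itself or from the loss of ((trifluoromethyl)carbonyl)amino, a question that a plain methoxy group or a chlorine atom at this position could help to settle. Also open, from the compounds shown here alone, is how an amine or a carboxylic acid at this position would read in this assay, and how much the 2-fluorophenyl group on the other side contributes to the value of compound 3.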